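Ester to Acid at the Edge of Detection

A few compounds are considered here, and "the series" means these few. Any claim that something is new, unique, unknown or untested is made for them only; others in the source may bear on it.

compound 1 `COC(=O)CC1=CC(=O)C(OC)=CC1=O`: 150000 nM
compound 2 `COC(=O)C1OC1(C)c1ccccc1`: 120000 nM
compound 3 `C=C(c1ccccc1)C(O)C(=O)OC`: > 900000 nM

All three were tested in an assay for inhibition of 4-hydroxyphenylpyruvate dioxygenase (Sus scrofa); on this read-out higher numbers stand for weaker inhibition and lower numbers for stronger inhibition. Compound 1 gives 150000 nM and compound 2 gives 120000 nM in this assay. For compound 3 the assay reports only a limit, > 900000 nM, not a number. Compound 3 therefore stands at the limit of > 900000 nM in this assay, at which 1 of the 3 values shown sits, the weakest end of what has been measured.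

Compound 4 `C=C(c1ccccc1)C(O)C(=O)O` differs from compound 3 by hydrogen in place of methyl on an oxygen next to a carbonyl group. For the measured compounds named here, no measured pair shows this same change, so its size is unknown from the data. A step within the scatter, or at most a small gain, is expected for a number no higher from compound 3 to compound 4 (the limit leaves the size open). Compound 4 is estimated at 900000 nM, with a range from 300000 nM to 3000000 nM, and the assay may again return only a limit.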

Compound 4, half-maximal inhibitory concentration: > 900000 nM
Compound 4: no number, only a limit; the forecaster's own chance of this, stated with the estimate: 60%; the middle value lies on the limit itself.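

For the compounds shown here, compound 3 and compound 4 both give only a limit rather than a number, so no step between them can be read: the limit of > 900000 nM in this assay, at which 2 of the 4 values shown sit. From the compounds shown here alone, whether hydrogen in place of methyl on this oxygen changes inhibition at all stays open.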